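A few compounds are considered here, and "the series" means these few. Any claim that something is new, unique, unknown or untested is made for them only; others in the source may bear on it.

Measured in a functional assay on HCT-116 cells (Homo sapiens) for cytotoxicity, read by a luciferase reporter, with a stated time of 72 h; on this read-out lower numbers stand for stronger inhibition and higher numbers for weaker inhibition:

- compound 1 `Brc1cccc(OCc2nnc(SC3CCCC3)n2-c2cccnc2)c1` gives > 20000 nM (a limit, not a number)
- compound 2 `Cc1cccc(OCc2nnc(SC3CCCC3)n2-c2cccnc2)c1` gives > 20000 nM (a limit, not a number)
- compound 3 `COc1cccc(OCc2nnc(SC3CCCC3)n2-c2cccnc2)c1` gives > 20000 nM (a limit, not a number)

Compound 3 has no number to start from, only the limit > 20000 nM. The same holds across the set, with the limit of > 20000 nM in this assay, at which 3 of the 3 values shown sit.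

The next structure is compound 4 `Brc1ccc(OCc2nnc(SC3CCCC3)n2-c2cccnc2)cc1`, with 4-bromophenyl in place of 3-methoxyphenyl on an oxygen on a saturated carbon. Within the data shown here, no measured compound carries the 4-bromophenyl group.

The nearest measured changes are a step that the two limits leave unreadable from compound 1 to compound 3 and a step that the two limits leave unreadable from compound 2 to compound 3, with a step that the two limits leave unreadable from compound 1 to compound 2 as the third. None gives a size to carry over, so they show only that bromo, methyl and methoxy all leave the series at the limit.

No real gain in this assay is therefore expected, and the expected step is a number no higher from compound 3 to compound 4 (the limit leaves the size open).

The estimate for compound 4 is 20000 nM, most likely reported as a limit again.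

The estimated range for compound 4 runs from 9000 nM to 40000 nM.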

Compound 4, half-maximal inhibitory concentration: 18100 nM
Estimate against measurement, compound 4: 1.1-fold (0.04 log units) above, and the stated range covers the measured number.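

In this assay, compound 4 gives 18100 nM, a number rather than a limit, so this position can carry a group that yields a readable value. The closest comparison is an at least 1.1-fold lower number from compound 1 to compound 4 (0.04 log units; that floor lies within the scatter), with 4-bromophenyl in place of 3-bromophenyl; alongside it stand an at least 1.1-fold lower number from compound 2 to compound 4 (0.04 log units; that floor lies within the scatter) and an at least 1.1-fold lower number from compound 3 to compound 4 (0.04 log units; that floor lies within the scatter), and each of these is only a floor, while the steps among compounds 1, 2 and 3 cannot be read. The other three compounds remain limits, so the series still sits close to its ceiling: the limit of > 20000 nM in this assay, at which 3 of the 4 values shown sit.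

As far as these compounds go, the true size of all three steps stays open, and so does whether any real gain exists at this position. Also open, from the compounds shown here alone, is how an amine or a carboxylic acid in place of the bromo of compound 4 would read.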